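Compound 1 to compound 4: diethylamino in place of anilino

The source may hold more compounds than are shown below. What is called first, only, known or untested is meant among the compounds shown, and "the series" means these compounds.

Measured so far in an ADME assay on LLC-PK11 cells (Sus scrofa) for cytotoxicity; a higher number here means a weaker inhibitor, a lower number a stronger inhibitor:
- Compound 1 `Clc1ccc2cc(NCCNc3nc(Cl)nc(Nc4ccccc4)n3)cnc2c1` gives 32800 nM
- Compound 2 `Clc1ccc2cc(NCCNc3nc(Nc4ccccc4)nc(Nc4ccccc4)n3)cnc2c1` gives 11200 nM
- Compound 3 `Clc1ccc2cc(NCCCCNc3nc(Nc4ccccc4)nc(Nc4ccccc4)n3)cnc2c1` gives 8800 nM

Compound 1, at 32800 nM in this assay, holds the highest number of the three, and its gap to each of the others lies beyond the scatter. Compound 2 and compound 3 lie within the scatter of each other.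

Still unmeasured is compound 4 `CCN(CC)c1nc(Cl)nc(NCCNc2cnc3cc(Cl)ccc3c2)n1`. The change from compound 1 is diethylamino in place of anilino on an aromatic carbon, which puts diethylamino in place of anilino on an aromatic carbon, opposite the ring nitrogen. Among the compounds with values here, only one measured step bears on this, and only indirectly: a 2.9-fold lower number from compound 1 to compound 2 (0.47 log units; beyond the scatter) is a modest step, with anilino in place of chloro. Within the data shown here, compound 4 keeps that chloro group, and no measured step removes an anilino group. As far as these compounds go, the data therefore give no direct guide to this swap, and the direction stays open, with a slight lean towards a lower number. In this assay the expected step is no larger than modest, and most likely none beyond the scatter. The estimated step is a 1.3-fold lower number from compound 1 to compound 4 (0.12 log units; within the scatter) in size, within the scatter. For compound 4 the estimated value is 25000 nM, with an expected range from 10000 nM to 60000 nM as its ends.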

Compound 4, half-maximal inhibitory concentration: 32000 nM
The estimate for compound 4 lay 1.3-fold (0.11 log units) below the measured number; low and high end bracket the measured number.
By their numbers in this assay, from the lowest: compounds 3 and 2 (each within the scatter of the next); then compounds 4 and 1 (each within the scatter of the next).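

In this assay, the swap of anilino for diethylamino on the aromatic carbon opposite the ring nitrogen gives a 1.0-fold lower number from compound 1 to compound 4 (0.01 log units; within the scatter), so compound 1 and compound 4 cannot be told apart at this position. Within the data shown here, this holds even though diethylamino carries neither the six-membered aromatic ring of carbon only nor the hydrogen-bond donor of the anilino group it takes the place of, which the earlier compounds did not test. Among these compounds, the only earlier single-place step, a 2.9-fold lower number from compound 1 to compound 2 (0.47 log units; beyond the scatter), concerned the chloro group instead, so with that chloro group kept, this pair gives no sign that the anilino group at this position matters for the read-out, and no supporting measurement accounts for this result.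

As far as these compounds go, whether a cyclic amine such as morpholino, or a smaller one such as dimethylamino, would also leave the number indistinguishable at this position remains open. Also open, from the compounds shown here alone, is whether the same swap would read the same way with a second anilino group in place of the chloro group, or with the longer chain of compound 3.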